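A few compounds are considered here, and "the series" means these few. Any claim that something is new, unique, unknown or untested is made for them only; others in the source may bear on it.

Three compounds share one core and differ only in the group on an amine nitrogen in a ring. Compound 1 `COc1ccc2nccc(C3CN(C4CCN(Cc5cc6ccccc6s5)CC4)C(=O)O3)c2c1` gives 794 nM in an in vitro functional assay on RBL cells for antagonist activity at C-C chemokine receptor type 8 (Homo sapiens), read by FLIPR and calcium flux; a lower number here means a stronger inhibitor, a higher number a weaker inhibitor; compound 2 `COc1ccc2nccc(C3CN(C4CCN(CCCc5ccccc5)CC4)C(=O)O3)c2c1` gives 251 nM in this assay; compound 3 `COc1ccc2nccc(C3CN(C4CCN(C(=O)c5ccc(Cl)c(Cl)c5)CC4)C(=O)O3)c2c1` gives 6310 nM in this assay. Compound 3 therefore stands highest of the three numbers, with a 7.9-fold higher number from compound 1 to compound 3 (0.90 log units; beyond the scatter) and a 25-fold higher number from compound 2 to compound 3 (1.40 log units; beyond the scatter), so that the (3,4-dichlorophenyl)carbonyl group is the weakest arrangement measured so far. Compound 4 `COc1ccc2nccc(C3CN(C4CCN(S(=O)(=O)c5ccc(Cl)c(Cl)c5)CC4)C(=O)O3)c2c1` now follows from compound 3 by the change ((3,4-dichlorophenyl)sulfonyl in place of (3,4-dichlorophenyl)carbonyl on an amine nitrogen in a ring). Among the compounds with values here, both measured steps that lead to compound 3 swap a chain carbon on that nitrogen for a carbonyl, and no measured step tests a sulfonyl in this position, so the (3,4-dichlorophenyl) group is kept and only the linking atom changes. On that basis the expected step in this assay from compound 3 is none beyond the scatter, a 1.1-fold lower number from compound 3 to compound 4 (0.02 log units; within the scatter). Compound 4 is therefore estimated at 6000 nM, within 2000 nM to 20000 nM.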

Compound 4, half-maximal inhibitory concentration: < 50200 nM
Compound 4: no number, only a limit; the forecaster's own chance of this, stated with the estimate: 15%; the middle value does not contradict the limit.
By their numbers in this assay, from the lowest: compound 2; then compound 1; then compound 3.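

In this assay compound 4 gives < 50200 nM, which is a limit and not a number. Within the data shown here, no step from compound 1, compound 2 or compound 3 to compound 4 can be read. The compounds shown leave open how the (3,4-dichlorophenyl)sulfonyl group of compound 4 compares with the (3,4-dichlorophenyl)carbonyl group of compound 3.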